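Amine variation on the shared core

The source may hold more compounds than are shown below. What is called first, only, known or untested is meant among the compounds shown, and "the series" means these compounds.

All values below come from an assay on isolated protein for binding affinity to 5-hydroxytryptamine receptor 6 (Homo sapiens); a lower number here means a stronger inhibitor, a higher number a weaker inhibitor.
compound 1, `COc1ccccc1-c1cc(C2CCNC2)ccc1Cl`: 400 nM
compound 2, `COc1ccccc1-c1cc(C2CCN(C)C2)ccc1Cl`: > 10000 nM, a limit of the assay
compound 3, `CCNCc1ccc(Cl)c(-c2ccccc2OC)c1`: 1400 nM

Compound 3 has the highest of the two numbers given in this assay; the nearest is compound 1, with a 3.5-fold higher number from compound 1 to compound 3 (0.54 log units; beyond the scatter). Compound 2 sits at the limit of > 10000 nM in this assay, at which 1 of the 3 values shown sits, and gives no number. The step of an at least 25-fold higher number from compound 1 to compound 2 (1.39 log units; beyond the scatter) is the only methyl addition measured, and it sits on an amine nitrogen in a ring. The step of an at least 7.1-fold lower number from compound 2 to compound 3 (0.85 log units; beyond the scatter) can only be read against that limit.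

Compound 4, `CCCNCc1ccc(Cl)c(-c2ccccc2OC)c1`, differs from compound 3 by methyl in place of hydrogen on a saturated chain carbon, two bonds along the chain from an amine nitrogen. Among the measured compounds shown here, no measured step changes a saturated chain carbon, so the methyl-on-nitrogen step from compound 1 to compound 2 does not transfer directly; in this assay the chain extension is expected to give only a small change, likely a slightly higher number, and the expected step is a 1.4-fold higher number from compound 3 to compound 4 (0.15 log units; within the scatter). Compound 4 is therefore estimated at 2000 nM in this assay, within the range 700 nM to 6000 nM.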

Compound 4, inhibition constant: 3500 nM
Estimate against measurement, compound 4: 1.8-fold (0.24 log units) below; low and high end bracket the measured number.
By their numbers in this assay, from the lowest: compound 1; then compound 3; then compound 4. At a limit, above all of these: compound 2.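

In this assay, among the compounds shown here, the change from ethylamino to propylamino is the first measured change on a saturated chain carbon, and it gives a 2.5-fold higher number from compound 3 to compound 4 (0.40 log units; beyond the scatter), so a methyl added two bonds along the chain from an amine nitrogen also raises the number, as the methyl on the amine nitrogen in a ring did (an at least 25-fold higher number from compound 1 to compound 2 (1.39 log units; beyond the scatter)), though that earlier step ends at a limit. Against the pyrrolidin-3-yl group, (propylamino)methyl on the same aromatic carbon gives an 8.8-fold higher number from compound 1 to compound 4 (0.94 log units; beyond the scatter), which leaves the pyrrolidin-3-yl group with the lowest number among the compounds that have one. The step of an at least 2.8-fold lower number from compound 2 to compound 4 (0.45 log units; beyond the scatter) can only be read against a limit. Compound 2 carries that limit: the limit of > 10000 nM in this assay, at which 1 of the 4 values shown sits.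

Whether the number keeps rising along the chain is open, since a butylamino group would test this, and a methylamino group would show whether shortening the chain from ethylamino lowers it. Also open, going by these compounds, is whether a methyl on the nitrogen of the ethylamino group raises the number as steeply as the methyl on the ring nitrogen does.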